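Trimethoxyphenyl to nitrophenyl on a hydroxynaphthoquinone-indole scaffold

The source may hold more compounds than are shown below. What is called first, only, known or untested is meant among the compounds shown, and "the series" means these compounds.

Measured compounds:
compound 1 `COc1cc(C(C2=C(O)C(=O)c3ccccc3C2=O)c2c[nH]c3ccc(Br)cc23)cc(OC)c1OC` 9710 nM
compound 2 `O=C1C(O)=C(C(c2cccc([N+](=O)[O-])c2)c2c(-c3ccccc3)[nH]c3ccccc23)C(=O)c2ccccc21` 12500 nM

Of the compounds shown here, two have been tested in a functional assay on HeLa cells (Homo sapiens) for cytotoxicity, read by MTT assay, with a stated time of 48 h; on this read-out higher numbers stand for weaker inhibition and lower numbers for stronger inhibition. Compound 1 `COc1cc(C(C2=C(O)C(=O)c3ccccc3C2=O)c2c[nH]c3ccc(Br)cc23)cc(OC)c1OC` gives 9710 nM, the lower of the two numbers. Compound 2 `O=C1C(O)=C(C(c2cccc([N+](=O)[O-])c2)c2c(-c3ccccc3)[nH]c3ccccc23)C(=O)c2ccccc21` gives 12500 nM in this assay, and the gap between compound 1 and compound 2 lies within the usual scatter, so the two cannot be told apart on these numbers. Both sit at the weak end of the range in this assay.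

Compound 3 `O=C1C(O)=C(C(c2ccc([N+](=O)[O-])cc2)c2c[nH]c3ccc(Br)cc23)C(=O)c2ccccc21` is yet to be measured. It differs from compound 1 in one place: 4-nitrophenyl in place of 3,4,5-trimethoxyphenyl on a saturated chain carbon bound to an aromatic carbon and a double-bonded ring carbon. Among the compounds with values here, no step between measured compounds describes this swap, so there is no direct guide to its size. Within the data shown here, because compound 1 stands at 9710 nM and compound 2, with a different aryl group in the same region, stands at 12500 nM, the series so far shows little spread, and the step from compound 1 to compound 3 is expected to be small, with no direction beyond the scatter: a 1.1-fold higher number from compound 1 to compound 3 (0.05 log units; within the scatter). Compound 3 is therefore estimated at 11000 nM in this assay, with a range from 4000 nM to 35000 nM.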

Compound 3, half-maximal inhibitory concentration: 14100 nM
For compound 3 the middle estimate is 1.3-fold (0.11 log units) below the measured one; the range from low to high includes it.
By their numbers in this assay, from the lowest: compounds 1, 2 and 3 (each within the scatter of the next).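

In this assay, placing 4-nitrophenyl where 3,4,5-trimethoxyphenyl stood, on a saturated chain carbon bound to an aromatic carbon and a double-bonded ring carbon, gives a step that can be read on its own (a 1.5-fold higher number from compound 1 to compound 3 (0.16 log units; within the scatter)). Compound 2 differs from compound 1 in more than one place and could not isolate this position, whereas this pair shows that, on the core of compound 1, the two aryl groups cannot be told apart, even though 12 heavy atoms leave and 9 enter, and the three methoxy groups give way to a single nitro group. No measurement shown here bears on what lies behind this result.

The compounds shown leave open whether anything at this position can move the number beyond the scatter, for instance an unsubstituted phenyl, a carboxylic acid on the ring or an open-chain amine in place of the ring. They also leave open whether the bromine on the shared core contributes at all, since a matching compound without it, or with chlorine instead, does not stand among them.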